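Working notes: bromo in place of hydrogen, compound 4

The compounds below may be only part of what the source reports. "The series", "measured", "known", "first", "only" and "open" are said of these compounds alone.

Values from a functional assay on HeLa cells (Homo sapiens) for inhibition (on this read-out higher numbers stand for weaker inhibition and lower numbers for stronger inhibition), are as follows
compound 1 `O=C1O/C(=C\Cn2cc(C(F)(F)F)c(=O)[nH]c2=O)C(OCc2ccccc2)=C1OCc1ccccc1` gives 20000 nM
compound 2 `O=C1O/C(=C\Cn2ccc(=O)[nH]c2=O)C(OCc2ccccc2)=C1OCc1ccccc1` gives 50000 nM
compound 3 `O=C1O/C(=C\Cn2cnc3c(-n4cccc4)ncnc32)C(OCc2ccccc2)=C1OCc1ccccc1` gives 70000 nM

Compound 2 lies within the scatter of compound 3, and its number stands above that of compound 1 by more than the scatter. Compound 4 `O=C1O/C(=C\Cn2cc(Br)c(=O)[nH]c2=O)C(OCc2ccccc2)=C1OCc1ccccc1` carries bromo in place of hydrogen on an aromatic carbon of compound 2 (bromo in place of hydrogen on an aromatic carbon). Among the measured compounds shown here, the one measured step at that carbon is a 2.5-fold higher number from compound 1 to compound 2 (0.40 log units; beyond the scatter) with hydrogen in place of trifluoromethyl. Read in reverse, this modest step suggests a group there may lower the number. A similar modest step to a lower number in this assay is expected (a 1.9-fold lower number from compound 2 to compound 4 (0.27 log units; within the scatter)), although a single step gives thin support. For compound 4 the estimated value is 27000 nM (12000 nM to 55000 nM expected range).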

Compound 4, half-maximal inhibitory concentration: 30000 nM
Compound 4: middle estimate off by 1.1-fold (0.05 log units), on the low side; low and high end bracket the measured number.
By their numbers in this assay, from the lowest: compounds 1, 4, 2 and 3 (each within the scatter of the next, the first and the last beyond it).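

In this assay, bromo in place of hydrogen on this aromatic carbon gives a 1.7-fold lower number from compound 2 to compound 4 (0.22 log units; within the scatter) and so does not separate from hydrogen, whereas the trifluoromethyl and hydrogen pair did separate. Bromo in place of trifluoromethyl gives a 1.5-fold higher number from compound 1 to compound 4 (0.18 log units; within the scatter) and so leaves those two groups unresolved at this position as well. No measured data on hand explain these steps. Still open, from the compounds shown here alone, is how an amine, a carboxylic acid or a methoxy group on this carbon would read out in this assay against hydrogen and trifluoromethyl.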